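The source may hold more compounds than are shown below. What is called first, only, known or untested is meant among the compounds shown, and "the series" means these compounds.

Going by the values given here, in an ADME assay on MCF7 cells for inhibition of cytochrome P450 26A1 (Homo sapiens) (a higher number here means a weaker inhibitor, a lower number a stronger inhibitor), compound 2 `O=C1c2ccc(O)cc2CCC1Cc1ccc(O)cc1` gives 20000 nM, the highest of the two numbers measured so far. Among the compounds with values here, its nearest neighbour, compound 1 `COc1ccc2c(c1)CCC(Cc1ccc(O)cc1)C2=O`, gives 5000 nM, and the only measured step, a 4.0-fold higher number from compound 1 to compound 2 (0.60 log units; beyond the scatter), came with hydrogen in place of methyl on an oxygen on an aromatic ring. Compound 3 `O=C1c2ccc(O)cc2CCC1Cc1ccc(-c2ccccc2)cc1` differs from compound 2 by phenyl in place of hydroxy on an aromatic carbon. Within the data shown here, no measured step involves an exchange of phenyl for hydroxy, so the direction of this change is open and the estimate must stay broad. Compound 3 is expected at about 20000 nM, between 3000 nM and 150000 nM, a step of no change at the digits printed from compound 2 to compound 3 (within the scatter).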

Compound 3, half-maximal inhibitory concentration: 10000 nM
For compound 3 the middle estimate is 2.0-fold (0.30 log units) above the measured one; the range from low to high includes it.
By their numbers in this assay, from the lowest: compounds 1, 3 and 2 (each within the scatter of the next, the first and the last beyond it).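

In this assay, phenyl in place of hydroxy on this aromatic carbon gives a 2.0-fold lower number from compound 2 to compound 3 (0.30 log units; within the scatter). The earlier step concerned only the other aromatic oxygen, whereas this one shows that a group of 6 heavy atoms, with 0 hydrogen-bond donors, can replace the hydroxy here without a difference beyond the scatter. Nothing available explains this result. Going by these compounds, whether an amine, a carboxylic acid or a longer chain on this carbon would give a number beyond the scatter stays open. So does the effect of phenyl here in the core of compound 1.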